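Threonine amide series: acyl group change and cell cytotoxicity

The compounds below may be only part of what the source reports. "The series", "measured", "known", "first", "only" and "open" are said of these compounds alone.

Measured compounds:
compound 1 `CCCCCCCCCCCCNC(=O)[C@@H](NC(=O)/C=C/c1ccccc1)[C@@H](C)O` — > 200000 nM
compound 2 `CCCCCCCCCCCCCCNC(=O)[C@@H](NC(=O)c1ccccc1)[C@@H](C)O` — 54200 nM
compound 3 `CCCCCCCCCCCCCCNC(=O)[C@@H](NC(=O)c1cccs1)[C@@H](C)O` — 88400 nM

In a functional assay on HepG2 cells (Homo sapiens) for cytotoxicity, read by MTT assay, with a stated time of 48 h (a lower number here means a stronger inhibitor, a higher number a weaker inhibitor), compound 2 gives 54200 nM. Compound 3 gives 88400 nM, the higher of the two numbers, and the step of a 1.6-fold higher number from compound 2 to compound 3 (0.21 log units; within the scatter) lies within the scatter. For compound 1 the result is a limit, > 200000 nM (the limit of > 200000 nM in this assay, at which 1 of the 3 values shown sits).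

Compound 4 `CCCCCCCCCCCCCCNC(=O)[C@@H](NC(=O)/C=C/c1ccccc1)[C@@H](C)O` differs from compound 3 by 2-phenylethenyl in place of thiophen-2-yl on a carbonyl carbon. For the measured compounds named here, the one measured step concerns a different acyl exchange and is within the scatter, so it says little about this one; compound 1, which carries the same 2-phenylethenyl group on a carbonyl carbon, reached only a limit. A weaker value is therefore expected, as a 1.7-fold higher number from compound 3 to compound 4 (0.23 log units; within the scatter), with a fair chance that only a limit is reported. Compound 4 is expected at 150000 nM, range 60000 nM to 400000 nM.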

Compound 4, half-maximal inhibitory concentration: 150000 nM
Compound 4: middle estimate and measured number agree at the digits printed, within the range that was stated.
By their numbers in this assay, from the lowest: compounds 2, 3 and 4 (each within the scatter of the next, the first and the last beyond it). At a limit, above all of these: compound 1.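

For the compounds shown here, at this carbonyl carbon, 2-phenylethenyl in place of phenyl gives the first acyl step beyond the scatter, though a modest one: a 2.8-fold higher number from compound 2 to compound 4 (0.44 log units; beyond the scatter). In this assay, the same group in place of thiophen-2-yl gives a 1.7-fold higher number from compound 3 to compound 4 (0.23 log units; within the scatter), while ethyl in place of hydrogen on the saturated chain gives an at least 1.3-fold lower number from compound 1 to compound 4 (0.12 log units; that floor lies within the scatter), a step that can be read only as a floor. The result for compound 1 is a limit: the limit of > 200000 nM in this assay, at which 1 of the 4 values shown sits.

On these data alone, how an acyl group carrying an amine or a carboxylic acid would read here remains open. So does the effect of a longer chain on the shared core.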